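The source may report more compounds than this note shows. Statements on the series, on what has been measured and on what is new or still open speak of the compounds shown alone.

Of the compounds shown here, three have been measured in a physicochemical assay for solubility, in simulated intestinal fluid; a higher number here means a more soluble compound, a lower number a less soluble compound. Compound 1 `Cn1cc(-c2nc3c(-c4ccc(C5(NC(=O)c6nc(C(C)(C)C)no6)CC5)cc4)ccnc3[nH]2)cn1` gives 56 ug/mL. Compound 2 `Cn1cc(-c2nc3c(-c4ccc5c(c4)CCC[C@@H]5NC(=O)c4nc(C(C)(C)C)no4)ccnc3[nH]2)cn1` gives 190 ug/mL. Compound 3 `Cc1nn(C(C)C)c(C)c1-c1nc2c(-c3ccc4c(c3)CCC[C@H]4NC(=O)c3nc(C(C)(C)C)no3)ccnc2[nH]1` gives 56 ug/mL. Compound 2 therefore stands highest of the three, and its gaps to both compound 1 and compound 3 are beyond the usual scatter of this kind of measurement, so the difference is a real one rather than noise.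

The compound still to be measured is compound 4 `CC(C)n1cc(-c2nc3c(-c4ccc5c(c4)CCC[C@@H]5NC(=O)c4nc(C(C)(C)C)no4)ccnc3[nH]2)cn1`. It is built from compound 2 by a single change: isopropyl in place of methyl on an aromatic nitrogen. Among the measured compounds shown here, no pair of measured compounds differs by this same change, so there is no direct precedent for how large a step to expect. Compound 3, which also carries an isopropyl on an aromatic nitrogen, sits at 56 ug/mL, but it differs from compound 2 in more than one place, so its value alone cannot be read as the effect of this change.

With that in mind, compound 4 is expected to come out somewhat lower than compound 2, with an estimated step of a 2.2-fold lower number from compound 2 to compound 4 (0.35 log units; beyond the scatter), a step that may or may not reach beyond the scatter. The estimated value for compound 4 in this assay is 85 ug/mL, within a range from 35 ug/mL to 200 ug/mL.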

Compound 4, solubility: 25 ug/mL
Compound 4: the middle estimate sits 3.4-fold (0.53 log units) above what was measured; the whole stated range lies above it.
By their numbers in this assay, from the lowest: compound 4; then compounds 1 and 3 (each within the scatter of the next); then compound 2.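

In this assay, among the compounds shown here, the switch from 1-methyl-1H-pyrazol-4-yl to 1-isopropyl-1H-pyrazol-4-yl gives a 7.6-fold lower number from compound 2 to compound 4 (0.88 log units; beyond the scatter), the first reading of this change with everything else in the molecule held constant. The group on this aromatic nitrogen therefore matters to the read-out, even though the change only takes the substituent from 1 heavy atom to 3, all carbon, with no ring, no hydrogen-bond donor or acceptor and no net charge entering or leaving. Nothing in the data shown explains why the number falls by this much.

This is a single pair, so it leaves open whether the same change would give a step of similar size on a different core, such as that of compound 1, which carries the methyl group but has no isopropyl partner here. It also leaves open how the number would respond to other groups on the same nitrogen, such as ethyl, a chain ending in an amine, or a chain ending in a carboxylic acid.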